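Hydrogen in place of bromo on compound 2

The source may hold more compounds than are shown below. What is called first, only, known or untested is meant among the compounds shown, and "the series" means these compounds.

In a physicochemical assay for lipophilicity (a higher number here means a more lipophilic compound, a lower number a more polar compound), compound 1 (`C[C@H]1CC[C@@H]2[C@@H](OC(=O)[C@]23CC(c2ccccc2)=NO3)[C@]2(C)C(=O)C=C[C@@]12O`) gives 1.41. Compound 2 (`C[C@H]1CC[C@@H]2[C@@H](OC(=O)[C@]23CC(c2ccc(Br)cc2)N(c2ccccc2)O3)[C@]2(C)C(=O)C=C[C@@]12O`) gives 4, the higher of the two numbers, and the gap between them lies beyond the scatter. Compound 3 (`C[C@H]1CC[C@@H]2[C@@H](OC(=O)[C@]23CC(c2ccccc2)N(c2ccccc2)O3)[C@]2(C)C(=O)C=C[C@@]12O`) has hydrogen in place of bromo on an aromatic carbon, a change from 4-bromophenyl to phenyl: hydrogen in place of bromo on an aromatic carbon. Within the data shown here, no measured pair isolates this change, so the expectation rests on the structural change alone. A fall beyond the scatter in this assay is expected, estimated as a number 0.70 log units lower from compound 2 to compound 3 (beyond the scatter). For compound 3 the estimated value is 3.3, with an expected range of 2.9 to 3.7.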

Compound 3, partition coefficient: 3.19
Compound 3: middle estimate off by 0.11 log units, on the high side, and the stated range covers the measured number.
By their numbers in this assay, from the lowest: compound 1; then compound 3; then compound 2.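

Replacing bromo with hydrogen on the aromatic carbon para to a large group, the change from 4-bromophenyl to phenyl, gives a number 0.81 log units lower from compound 2 to compound 3 (beyond the scatter) in this assay. This is the first reading in the series of a change at one place, so this position is shown to register in this assay beyond the scatter. Nothing available bears on the cause of this step.

One pair gives one substituent comparison at one position. As far as these compounds go, how chloro, an amine or a carboxylic acid at this position would compare with bromo and hydrogen remains open.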